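Amide aryl change from compound 2 to compound 3

A few compounds are considered here, and "the series" means these few. Any claim that something is new, unique, unknown or untested is made for them only; others in the source may bear on it.

Going by the values given here, in a functional assay on GTL 16 cells for antiproliferative activity against GTL 16 cell line (Homo sapiens), read by CCK-8 assay, with a stated time of 72 h (a higher number here means a weaker inhibitor, a lower number a stronger inhibitor), compound 2 `Cc1ccccc1C(=O)Nc1cccc(-c2oc3cc(-c4ccc(F)cc4)ccc3c(=O)c2O)c1` gives 24800 nM, the higher of the two numbers measured so far; compound 1 `COc1ccccc1C(=O)Nc1cccc(-c2oc3cc(-c4ccc(F)cc4)ccc3c(=O)c2O)c1` gives 6370 nM. Among the compounds with values here, the only measured step, a 3.9-fold higher number from compound 1 to compound 2 (0.59 log units; beyond the scatter), concerns methyl in place of methoxy on an aromatic carbon of the amide aryl group. Compound 3 `O=C(Nc1cccc(-c2oc3cc(-c4ccc(F)cc4)ccc3c(=O)c2O)c1)c1ccc(C(F)(F)F)cc1` carries 4-(trifluoromethyl)phenyl in place of 2-methylphenyl on a carbonyl carbon. Within the data shown here, no measured step covers this change directly; the one step seen shows only that this aryl group can shift the number modestly. The step of a 2.1-fold lower number from compound 2 to compound 3 (0.32 log units; beyond the scatter) is therefore expected to be small, direction uncertain. Compound 3 is estimated at 12000 nM, range 3000 nM to 40000 nM.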

Compound 3, half-maximal inhibitory concentration: 33000 nM
Beside the measured number, compound 3's estimate is 2.8-fold (0.44 log units) below it; low and high end bracket the measured number.
By their numbers in this assay, from the lowest: compound 1; then compounds 2 and 3 (each within the scatter of the next).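

In this assay, moving from 2-methylphenyl to 4-(trifluoromethyl)phenyl on the carbonyl carbon gives a 1.3-fold higher number from compound 2 to compound 3 (0.12 log units; within the scatter), so these two aryl groups are not separated. The same group set against 2-methoxyphenyl gives a 5.2-fold higher number from compound 1 to compound 3 (0.71 log units; beyond the scatter), so among these three amides only compound 1 stands apart from both others. No evidence on the reason for this is available.

Still open, from the compounds shown here alone, is whether 2-methoxyphenyl owes its lower number to the methoxy group or to where it sits. A 4-methoxyphenyl, 2-ethoxyphenyl or 2-hydroxyphenyl group on the carbonyl carbon would bear on that.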